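Methylsulfanyl in Place of Methoxy: An Expected Antiproliferative Value

The compounds below may be only part of what the source reports. "The series", "measured", "known", "first", "only" and "open" are said of these compounds alone.

Three compounds share one core and differ only on a single six-membered aromatic ring. In a functional assay on MKN-74 cells (Homo sapiens) for antiproliferative activity, with a stated time of 24 h (on this read-out higher numbers stand for weaker inhibition and lower numbers for stronger inhibition), compound 1 `NC(=O)c1c(NC(=O)c2ccccc2)sc2c1CCN(C(=S)Nc1ccccc1Cl)C2` gives 11800 nM, compound 2 `Cc1ccccc1C(=O)Nc1sc2c(c1C(N)=O)CCN(C(=S)Nc1ccccc1Cl)C2` gives 11000 nM, and compound 3 `COc1ccccc1C(=O)Nc1sc2c(c1C(N)=O)CCN(C(=S)Nc1ccccc1Cl)C2` gives 20500 nM. Compound 3 stands at the high end of these three numbers, but the steps to it, a 1.7-fold higher number from compound 1 to compound 3 (0.24 log units; within the scatter) and a 1.9-fold higher number from compound 2 to compound 3 (0.27 log units; within the scatter), lie within the scatter, so the three are not truly separated. Compound 4 `CSc1ccccc1C(=O)Nc1sc2c(c1C(N)=O)CCN(C(=S)Nc1ccccc1Cl)C2` differs from compound 3 by methylsulfanyl in place of methoxy on an aromatic carbon. For the measured compounds named here, no measured step involves methylsulfanyl; the exchanges at this position, including a 1.1-fold lower number from compound 1 to compound 2 (0.03 log units; within the scatter), all stayed within the scatter. In this assay the change to compound 4 is therefore expected to be a 1.1-fold lower number from compound 3 to compound 4 (0.06 log units; within the scatter), nothing beyond the scatter. Compound 4 is estimated at 18000 nM, within 8000 nM to 40000 nM.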

Compound 4, half-maximal inhibitory concentration: 6550 nM
Beside the measured number, compound 4's estimate is 2.7-fold (0.44 log units) above it, outside the stated range (below it).
By their numbers in this assay, from the lowest: compounds 4, 2, 1 and 3 (each within the scatter of the next, the first and the last beyond it).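

For the compounds shown here, at this position, ortho to a large group, the exchange of methoxy for methylsulfanyl gives the first step beyond the scatter in this assay, with a 3.1-fold lower number from compound 3 to compound 4 (0.50 log units; beyond the scatter), so the exchanges here do not all stay within it. Compound 4 separates only from compound 3, since the other steps, a 1.7-fold lower number from compound 2 to compound 4 (0.23 log units; within the scatter) and a 1.8-fold lower number from compound 1 to compound 4 (0.26 log units; within the scatter), remain within the scatter. Nothing available accounts for the difference between methoxy and methylsulfanyl.

The compounds shown leave open whether a longer chain on the sulfur keeps this result, and whether an amine here would fall nearer methylsulfanyl or methoxy.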